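Sulfanyl side chain: from compound 3 to compound 4

The source may report more compounds than this note shows. Statements on the series, on what has been measured and on what is new or still open speak of the compounds shown alone.

In an ADME assay on GES1 cells (Homo sapiens) for inhibition, read by MTT assay, with a stated time of 72 h (on this read-out higher numbers stand for weaker inhibition and lower numbers for stronger inhibition), compound 1 `Cc1cc(Nc2cc(-c3ccccc3)[nH]n2)n2nc(SCc3ccc(F)cc3)nc2n1` gives 35500 nM, compound 2 `Cc1cc(Nc2cc(-c3ccccc3)[nH]n2)n2nc(SCc3ccc([N+](=O)[O-])cc3)nc2n1` gives 43600 nM and compound 3 `Cc1cc(Nc2cc(-c3ccccc3)[nH]n2)n2nc(SCc3ccccc3Br)nc2n1` gives 41100 nM. Compound 3 is not separated from the other two: the readings show a 1.2-fold higher number from compound 1 to compound 3 (0.06 log units; within the scatter) and a 1.1-fold lower number from compound 2 to compound 3 (0.03 log units; within the scatter).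

The next change leads to compound 4 `Cc1cc(Nc2cc(-c3ccccc3)[nH]n2)n2nc(SCc3nc4ccccc4[nH]3)nc2n1`, described by 1H-benzimidazol-2-yl in place of 2-bromophenyl on a saturated chain carbon bound to a sulfur. Here 1H-benzimidazol-2-yl stands in place of 2-bromophenyl on a saturated chain carbon bound to a sulfur. The two steps already given bear directly on this change, since each alters the aromatic group on that chain carbon. The step with nitro in place of fluoro, a 1.2-fold higher number from compound 1 to compound 2 (0.09 log units; within the scatter), bears on it as well. All three are small, and none leaves the scatter in this assay.

Among the compounds with values here, the evidence has a clear limit: no measured compound has a five-membered aromatic ring with 2 hetero atoms at this place. The new group is therefore a larger change than any measured so far, and the expected range has to be wide. No shift beyond the scatter is expected in either direction, and the expected step is a 1.1-fold lower number from compound 3 to compound 4 (0.06 log units; within the scatter). The estimate for compound 4 is 36000 nM, with an expected range from 16000 nM to 75000 nM.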

Compound 4, half-maximal inhibitory concentration: 27800 nM
For compound 4 the middle estimate is 1.3-fold (0.11 log units) above the measured one; low and high end bracket the measured number.
By their numbers in this assay, from the lowest: compounds 4, 1, 3 and 2 (each within the scatter of the next).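

In this assay, 1H-benzimidazol-2-yl on a saturated chain carbon bound to a sulfur leaves the reading within the scatter of all three compounds with a substituted phenyl group (the steps are a 1.5-fold lower number from compound 3 to compound 4 (0.17 log units; within the scatter), a 1.6-fold lower number from compound 2 to compound 4 (0.20 log units; within the scatter), and a 1.3-fold lower number from compound 1 to compound 4 (0.11 log units; within the scatter)). The earlier compounds shown here varied only the substituent and its place on a phenyl group, whereas this change brings in a five-membered aromatic ring with 2 hetero atoms, a hydrogen-bond donor and a hydrogen-bond acceptor, and even this larger change gives no step beyond the scatter, so the four compounds cannot be ranked at this position. No measurement at hand bears on why the reading for this group falls where it does.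

Still open, on these data alone, is whether a non-aromatic group at this place, such as an amine or a carboxylic acid on the chain carbon, or a longer chain bound to the sulfur, would give a step beyond the scatter. As far as these compounds go, all four compounds share one core, so the effect of changes elsewhere also remains open.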